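The source may hold more compounds than are shown below. What is called first, only, known or untested is meant among the compounds shown, and "the series" means these compounds.

Working notes on the series. In an ADME assay on microsomes from liver (Homo sapiens) for metabolic stability, read by LC-MS, using NADPH, tested at 5 uM (on this read-out lower numbers stand for a shorter-lived compound and higher numbers for a longer-lived compound), compound 3 `NS(=O)(=O)c1cc(-c2nnc(Cn3cc(-c4ccccc4)nn3)o2)c(Cl)cc1SCc1ccccc1` gives 0.21 h, the smallest of the three numbers shown, though all three lie within the scatter of one another: compound 2 `CC(C)(O)c1cn(Cc2nnc(-c3cc(S(N)(=O)=O)c(SCc4ccccc4)cc3Cl)o2)nn1` gives 0.23 h and compound 1 `NS(=O)(=O)c1cc(-c2nnc(CCl)o2)c(Cl)cc1SCc1ccccc1` gives 0.235 h. Compound 4 `NS(=O)(=O)c1cc(-c2nnc(CNS(=O)(=O)c3ccc(Cl)cc3)o2)c(Cl)cc1SCc1ccccc1` carries ((4-chlorophenyl)sulfonyl)amino in place of 4-phenyl-1H-1,2,3-triazol-1-yl on a saturated chain carbon bound to an aromatic carbon. Among the compounds with values here, the steps that bear on this place are a 1.1-fold lower number from compound 1 to compound 3 (0.05 log units; within the scatter) and a 1.0-fold lower number from compound 1 to compound 2 (0.01 log units; within the scatter), both within the scatter, and a 1.1-fold lower number from compound 2 to compound 3 (0.04 log units; within the scatter) likewise; every substitution tried on this saturated chain carbon so far has left this assay unmoved. For compound 4 the expected step is therefore a 1.0-fold higher number from compound 3 to compound 4 (0.02 log units; within the scatter), none beyond the scatter, and the estimate for compound 4 in this assay is 0.22 h, with a range from 0.11 h to 0.44 h.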

Compound 4, half-life: 0.197 h
Beside the measured number, compound 4's estimate is 1.1-fold (0.05 log units) above it; measured number inside the range.
By their numbers in this assay, from the lowest: compounds 4, 3, 2 and 1 (each within the scatter of the next).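

The triazole is not needed for this flat result: in this assay, ((4-chlorophenyl)sulfonyl)amino, with no triazole and with a hydrogen-bond donor, still gives a 1.1-fold lower number from compound 3 to compound 4 (0.03 log units; within the scatter), a 1.2-fold lower number from compound 2 to compound 4 (0.07 log units; within the scatter) and a 1.2-fold lower number from compound 1 to compound 4 (0.08 log units; within the scatter). Within the data shown here, four different groups on this saturated chain carbon, of which compound 4 adds the only sulfonyl-linked example, now stand within the scatter of one another. Nothing on hand bears on the reason for this result. Open, from the compounds shown here alone, is whether an amine or a carboxylic acid on this carbon would shift the half-life, and whether any change elsewhere on the shared core would do so.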